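Moving from compound 3 to compound 4 in kinase activation

The source may report more compounds than this note shows. Statements on the series, on what has been measured and on what is new or still open speak of the compounds shown alone.

Compound 1 `Clc1cc(Cl)cc(CO[C@H]2CCCN(Cc3ccccc3)[C@H]2c2ccccc2)c1`: compound 1 gives > 200000 nM in an assay on isolated protein for activation of cGMP-dependent protein kinase 1 (Homo sapiens), read by ADP-Glo, with stated times of 120 min and 40 min (a higher number here means that more compound is needed for the effect, a lower number that less compound is needed), a limit of the assay.
Compound 2 `COc1cc(C(=O)O)ccc1CN1CCC[C@H](OCc2cc(Cl)cc(Cl)c2)[C@@H]1c1ccccc1`: compound 2 gives 62000 nM in this assay.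
Compound 3 `O=C(O)c1ccc(CN2CCC[C@H](OCc3cc(Cl)cc(Cl)c3)[C@@H]2c2ccccc2)cn1`: compound 3 gives > 200000 nM in this assay, a limit of the assay.

Compound 3 therefore stands only at a limit, and so does one further value shown (the limit of > 200000 nM in this assay, at which 2 of the 3 values shown sit). Compound 4 `COc1ccc(C(=O)O)cc1CN1CCC[C@H](OCc2cc(Cl)cc(Cl)c2)[C@@H]1c1ccccc1` differs from compound 3 in one place: 5-carboxy-2-methoxyphenyl in place of 6-carboxypyridin-3-yl on a saturated chain carbon bound to an amine nitrogen in a ring. Among the measured compounds shown here, two measured steps bear on this. The step of an at least 3.2-fold lower number from compound 1 to compound 2 (0.50 log units; beyond the scatter) shows a methoxyphenyl ring carrying a carboxy group giving a lower number than plain phenyl, and the step of an at least 3.2-fold higher number from compound 2 to compound 3 (0.50 log units; beyond the scatter) shows the carboxypyridinyl ring giving a higher number than that ring. Since compound 4 again carries a methoxyphenyl ring with a carboxy group, a step of about an at least 2.2-fold lower number from compound 3 to compound 4 (0.34 log units; beyond the scatter) toward a lower number is expected. Compound 4 is estimated at 90000 nM, within a range from 30000 nM to 200000 nM.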

Compound 4, half-maximal effective concentration: 123000 nM
Estimate against measurement, compound 4: 1.4-fold (0.14 log units) below, within the range that was stated.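

Exchanging 4-carboxy-2-methoxyphenyl for 5-carboxy-2-methoxyphenyl gives a 2.0-fold higher number from compound 2 to compound 4 (0.30 log units; within the scatter) in this assay, so these two substituted rings cannot be told apart here. Against 6-carboxypyridin-3-yl and plain phenyl, the readings are an at least 1.6-fold lower number from compound 3 to compound 4 (0.21 log units; that floor lies within the scatter) and an at least 1.6-fold lower number from compound 1 to compound 4 (0.21 log units; that floor lies within the scatter), so compound 4 is not shown to differ from either compound. Only these floors can be read because compound 1 and compound 3 each stand at a limit: the limit of > 200000 nM in this assay, at which 2 of the 4 values shown sit.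

Going by these compounds, it remains open how a primary amide or a tetrazole in place of the carboxy group would read at this place. Also open, on these data alone, is what the methoxy group contributes on a ring that keeps the carboxy group.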